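The compounds below may be only part of what the source reports. "The series", "measured", "known", "first", "only" and "open" are said of these compounds alone.

Within the data shown here, compound 2 `Cc1ccc(OCC(=O)N(Cc2cccs2)CC(C)C)cc1` gives 900 nM in an assay on HEK293 cells for agonist activity at transient receptor potential cation channel subfamily M member 8 (Homo sapiens), read by fluorescence and calcium flux, with a stated time of 15 min (on this read-out lower numbers stand for an effect already at smaller amounts and higher numbers for an effect only at larger amounts of compound), the highest of the two numbers measured so far. Its nearest neighbour is compound 1 `Cc1ccc(OCC(=O)N(Cc2cccs2)c2cccnc2)cc1`, which in this assay gives 198 nM. Among the measured compounds shown here, the one step available, a 4.5-fold higher number from compound 1 to compound 2 (0.66 log units; beyond the scatter), thus runs from an aromatic heterocycle on the amide-type nitrogen to a branched chain there. Compound 3 `Cc1ccc(OCC(=O)N(Cc2cccs2)c2ccnn2C)cc1` reverses that direction: 1-methyl-1H-pyrazol-5-yl in place of isobutyl on an amide-type nitrogen. For the measured compounds named here, since the move away from a heterocycle toward isobutyl was a 4.5-fold higher number from compound 1 to compound 2 (0.66 log units; beyond the scatter), a move back to a five-membered heterocycle with two hetero atoms is expected to lower the number again, though the ring differs from pyridin-3-yl and no step between two such heterocycles has been measured. The step from compound 2 to compound 3 is therefore expected to be a 3.0-fold lower number from compound 2 to compound 3 (0.48 log units; beyond the scatter) in this assay. Compound 3 is estimated to give 300 nM in this assay, within a range from 100 nM to 1000 nM.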

Compound 3, half-maximal effective concentration: 422 nM
Estimate against measurement, compound 3: 1.4-fold (0.15 log units) below, and the stated range covers the measured number.
By their numbers in this assay, from the lowest: compound 1; then compound 3; then compound 2.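

With a second ring type, the lower number for a heterocycle over isobutyl on the amide-type nitrogen holds for both compound 1 and compound 3, and none of the three compounds goes against it: in this assay the change to 1-methyl-1H-pyrazol-5-yl gives a 2.1-fold lower number from compound 2 to compound 3 (0.33 log units; beyond the scatter) in that direction. The two heterocycles are not interchangeable at this place, however, as replacing pyridin-3-yl with 1-methyl-1H-pyrazol-5-yl gives a 2.1-fold higher number from compound 1 to compound 3 (0.33 log units; beyond the scatter) and leaves compound 3 in the middle of the series. No measurement offered here explains this order.

The compounds shown leave open how a plain phenyl ring or a cyclohexyl ring on this nitrogen would compare. They also leave open what the methyl on the pyrazole ring contributes to the number.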